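Urea series: sulfamoyl to dimethylsulfamoyl on the aryl urea

This account rests on a few compounds, and the source may have more. Where it says the series, first, only, none or still open, it means among the compounds named here.

Measured so far:
compound 1 `CCOC(=O)c1ccc(N(C)C(=O)NCc2ccncc2)cc1` — > 100000 nM
compound 2 `NS(=O)(=O)c1ccc(NC(=O)NCc2ccncc2)cc1` — 14300 nM

In an assay on isolated protein for activation of Nicotinamide phosphoribosyltransferase (Homo sapiens) (a lower number here means that less compound is needed, a higher number that more compound is needed for the effect), compound 1 gives only a limit, > 100000 nM, not a number. Among the measured compounds shown here, compound 2 is the one member with a measured value, 14300 nM in this assay. The other entry sits at the limit of > 100000 nM in this assay, at which 1 of the 2 values shown sits, so compound 2 is the sole point of reference for the step below.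

Compound 3 `CN(C)S(=O)(=O)c1ccc(NC(=O)NCc2ccncc2)cc1` has not been measured in this assay. It differs from compound 2 in one place: dimethylamino in place of amino on a sulfonyl sulfur; cut one bond further out, sulfamoyl becomes dimethylsulfamoyl. For the measured compounds named here, no step between measured compounds covers a change of this kind, so nothing sets its size or direction.

The expectation is a modest loss in this assay, with the step from compound 2 to compound 3 estimated at a 2.8-fold higher number from compound 2 to compound 3 (0.45 log units; beyond the scatter). Compound 3 is expected to give about 40000 nM, within the range 10000 nM to 150000 nM, and there is a real chance that this assay reports only a limit for it.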

Compound 3, half-maximal effective concentration: 3110 nM
Estimate against measurement, compound 3: 13-fold (1.11 log units) above, outside the stated range (below it).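

In this assay, among the compounds shown here, dimethylamino in place of amino on a sulfonyl sulfur gives a 4.6-fold lower number from compound 2 to compound 3 (0.66 log units; beyond the scatter), the first measured evidence that this position responds to substitution and that the change can lower the number. The dimethylamino group carries no hydrogen-bond donor, so a donor on this sulfonyl sulfur is not required for the effect in this pair, and the added carbons are accommodated without a loss in this assay. No measurement shown here accounts for the size of this step.

This single pair cannot separate the removal of the donor from the addition of the two carbons, and methylamino on the same sulfonyl sulfur, which keeps a hydrogen on the nitrogen and adds one methyl, would address that directly. Also open, as far as these compounds go, is whether the trend continues with larger groups on this sulfur, such as diethylamino, pyrrolidine or morpholine, or whether dimethylamino is already close to the limit of what this position accepts.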